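Trifluoromethyl for fluoro on the aryl ring, compound 2 to compound 3

The compounds below may be only part of what the source reports. "The series", "measured", "known", "first", "only" and "open" are said of these compounds alone.

Measured compounds:
compound 1 `N/C(=N\CCC(c1ccc(O)cc1)c1ccccn1)NCCCc1c[nH]cn1` gives 6.63
compound 2 `N=C(NCCCc1c[nH]cn1)NCCC(c1ccc(F)cc1)c1ccccn1` gives 8.01

Of the compounds shown here, two have been measured in a functional assay on cardiac atrium for agonist activity at histamine H2 receptor (Cavia porcellus); on this read-out higher numbers stand for higher potency (the scale is a negative logarithm) and lower numbers for lower potency. Compound 2 holds the higher of the two numbers; compound 1 stands lower by a gap that lies beyond the usual scatter of this assay. Compounds 1 and 2 differ in the group on the aromatic carbon of the six-membered aromatic ring of carbon only, hydroxy against fluoro, and nothing more can be read from the pair than what the two values show.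

The next compound, compound 3 `N=C(NCCCc1c[nH]cn1)NCCC(c1ccc(C(F)(F)F)cc1)c1ccccn1`, carries trifluoromethyl in place of fluoro on an aromatic carbon, that is, trifluoromethyl in place of fluoro on an aromatic carbon, para to a large group. Among the compounds with values here, no step between measured compounds covers this change, so the direction is open. The expectation is a small step, if any, from compound 2 to compound 3 of a number 0.31 log units lower from compound 2 to compound 3 (beyond the scatter), most likely a slight loss rather than a gain. Compound 3 is therefore estimated at 7.7 in this assay, with a range from 7 to 8.4.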

Compound 3, negative logarithm of the half-maximal effective concentration: 7.76
Compound 3: middle estimate off by 0.06 log units, on the low side; low and high end bracket the measured number.
By their numbers in this assay, from the lowest: compound 1; then compounds 3 and 2 (each within the scatter of the next).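

In this assay, trifluoromethyl in place of fluoro on this aromatic carbon, para to a large group, gives a number 0.25 log units lower from compound 2 to compound 3 (within the scatter), so 4 heavy atoms in place of 1 heavy atom at this position leave a change that cannot be told from the scatter. With compound 3 at 7.76 and compound 1 at 6.63, the hydroxy compound now holds the lowest number of the three, and the pair of fluoro and trifluoromethyl compounds reads as one level on this read-out rather than as a single favourable substituent. The data at hand hold no measurement that bears on why the two groups read alike.

Open, on these data alone, is whether that level extends to other groups on the same aromatic carbon, such as chloro, methoxy, an amine or a carboxylic acid, which would show how far the tolerance at this position reaches. Also open, as far as these compounds go, is whether a fluoro or trifluoromethyl group keeps this level when the shared core changes elsewhere, for instance with a longer chain.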